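The source may hold more compounds than are shown below. What is called first, only, known or untested is meant among the compounds shown, and "the series" means these compounds.

Measured compounds in a functional assay on HeLa cells (Homo sapiens) for inhibition, read by cell counting, with a stated time of 4 days; a lower number here means a stronger inhibitor, a higher number a weaker inhibitor:

Compound 1, `CCc1ccc(-c2nn3cc(-c4cccc(N)c4)nc3s2)cc1`: 8100 nM
Compound 2, `CCOc1ccc(-c2nn3cc(-c4cccc(N)c4)nc3s2)cc1`: 94000 nM
Compound 3, `C=C(Br)C(=O)Nc1cccc(-c2cn3nc(-c4ccc(C)cc4)sc3n2)c1`: 2000 nM

Compound 3 has the lowest number of the three in this assay; compound 1 stands nearest to it and compound 2 furthest. Among the compounds with values here, the one step between compounds that differ in a single place, a 12-fold higher number from compound 1 to compound 2 (1.06 log units; beyond the scatter), concerns the group on the aryl ring away from the amine and does not touch the amide. Compound 3 and compound 1 differ in two places, so their values can only be read side by side, with compound 3 the lower.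

Compound 4, `Cc1ccc(-c2nn3cc(-c4cccc(N)c4)nc3s2)cc1`, is reached from compound 3 by the change (hydrogen in place of (1-bromoethenyl)carbonyl on a nitrogen on an aromatic ring); read one bond further out, this is ((1-bromoethenyl)carbonyl)amino becoming amino. The group that leaves carries two double bonds outside aromatic rings and a bromine. Within the data shown here, no measured step covers this change, so the expectation rests on the neighbourhood: compound 1, which also bears the free amino group, gives 8100 nM. Compound 4 is therefore expected to show a weaker result than compound 3, with a step of about a 4.5-fold higher number from compound 3 to compound 4 (0.65 log units; beyond the scatter), and an estimated value of 9000 nM, expected to lie between 3500 nM and 30000 nM.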

Compound 4, half-maximal inhibitory concentration: 8900 nM
Compound 4: the middle estimate sits 1.0-fold (0.00 log units) above what was measured; the measured number falls inside the stated range.
By their numbers in this assay, from the lowest: compound 3; then compounds 1 and 4 (each within the scatter of the next); then compound 2.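

In this assay, within the data shown here, taking the (1-bromoethenyl)carbonyl group off the nitrogen and leaving hydrogen gives a 4.5-fold higher number from compound 3 to compound 4 (0.65 log units; beyond the scatter), the first reading of this change in which nothing else differs, so on this pair the amide carrying that group has the lower number. Among the compounds with the free amino group, shortening ethyl to methyl on the aryl ring gives a 1.1-fold higher number from compound 1 to compound 4 (0.04 log units; within the scatter), so these two cannot be told apart, whereas methyl in place of ethoxy gives an 11-fold lower number from compound 2 to compound 4 (1.02 log units; beyond the scatter), and ethoxy now stands apart from both small alkyl groups rather than from ethyl alone. No measurement shown here offers a reason for any of these steps.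

From the compounds shown here alone, what a plain acetyl group or a propenoyl group without the bromine would give on the same nitrogen stays open, and so the share of the bromine and of the double bond in the step to the free amine cannot be separated. Also open, going by these compounds, is whether the same amide would shift the number equally with ethyl or ethoxy on the aryl ring, and how a propyl chain or a methoxy group there would compare.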